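Furan-3-yl to Phenyl: an Expected Modest Shift

A few compounds are considered here, and "the series" means these few. Any claim that something is new, unique, unknown or untested is made for them only; others in the source may bear on it.

Compound 1 `COc1ncnc2c1c(-c1ccoc1)cn2[C@@H]1O[C@H](CO)[C@@H](O)[C@H]1O`: 130 nM
Compound 2 `CN(C)c1ncnc2c1c(-c1ccoc1)cn2[C@@H]1O[C@H](CO)[C@@H](O)[C@H]1O`: > 20000 nM

Among the compounds with values here, compound 1 is the only compound with an actual number in a functional assay on HCT-116 cells (Homo sapiens), read by MTT assay, with a stated time of 72 h (a higher number here means a weaker inhibitor, a lower number a stronger inhibitor), where compound 1 gives 130 nM. Compound 2 sits at a limit of this assay, recorded as > 20000 nM, and this is a limit rather than a number. Within the data shown here, the single measured step, an at least 150-fold higher number from compound 1 to compound 2 (2.18 log units; beyond the scatter), is accordingly known only as a lower bound (the limit of > 20000 nM in this assay, at which 1 of the 2 values shown sits). Compound 3 `COc1ncnc2c1c(-c1ccccc1)cn2[C@@H]1O[C@H](CO)[C@@H](O)[C@H]1O` differs from compound 1 at a different place: phenyl in place of furan-3-yl on an aromatic carbon. Among the measured compounds shown here, no measured step touches the furan-3-yl; the one known step concerns the methoxy, so it offers no direct guide here. Compound 3 is therefore expected to stay close to compound 1, with a step of a 1.9-fold higher number from compound 1 to compound 3 (0.28 log units; within the scatter) not clearly beyond the scatter. The estimate for compound 3 is 250 nM, with a range from 50 nM to 1500 nM.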

Compound 3, half-maximal inhibitory concentration: > 20000 nM
Compound 3: no number, only a limit; the forecaster's own chance of this, stated with the estimate: 10%; middle value at least 80-fold (1.90 log units) away from the limit.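

The change from furan-3-yl to phenyl gives an at least 150-fold higher number from compound 1 to compound 3 (2.18 log units; beyond the scatter) in this assay, so the group on this aromatic carbon matters as much to the read-out as the methoxy does, and compound 1 loses its measurable activity through either single change shown. Compound 3 is recorded only at a limit, > 20000 nM, and this is not a number. The true size of the step therefore stays unknown, since it can be read only as a lower bound: the limit of > 20000 nM in this assay, at which 2 of the 3 values shown sit.

The compounds shown leave open whether a thiophene or a pyridine ring at this place would stay close to compound 1. They also leave open how a smaller group, such as a methyl or a chlorine atom, would read here.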